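A few compounds are considered here, and "the series" means these few. Any claim that something is new, unique, unknown or untested is made for them only; others in the source may bear on it.

Compound 1 `CCCc1nc2cccc(C(=O)O)c2n1Cc1ccc(-c2ccccc2-c2noc(O)n2)cc1`: 100%
Compound 2 `COc1nc2cccc(C(=O)O)c2n1Cc1ccc(-c2ccccc2-c2noc(O)n2)cc1`: 90%
Compound 3 `CCCOc1nc2cccc(C(=O)O)c2n1Cc1ccc(-c2ccccc2-c2noc(O)n2)cc1`: 100%

All three numbers come from a functional assay on the whole organism for inhibition, with Rattus norvegicus as the target, with a stated time of 3 h, at a dose of 1 mg/kg by the oral route; on this read-out lower numbers stand for less inhibition and higher numbers for more inhibition at the one dose given (going by the name of the read-out). Compound 3 stands level with compound 1 at the digits shown, the two together at the top of the three numbers, and the step of no change at the digits printed from compound 1 to compound 3 (within the scatter) is flat. Toward compound 2 the step of a number 10 percentage points higher from compound 2 to compound 3 (within the scatter) is small, as is the step of a number 10 percentage points lower from compound 1 to compound 2 (within the scatter), so none of the three exchanges on this aromatic carbon has moved the read-out beyond the usual scatter.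

Compound 4 `CSc1nc2cccc(C(=O)O)c2n1Cc1ccc(-c2ccccc2-c2noc(O)n2)cc1` has not yet been measured in this assay. It differs from compound 3 in one place: methylsulfanyl in place of propoxy on an aromatic carbon. Among the measured compounds shown here, no measured step introduces a sulfur-bearing group, so the nearest guides are the two flat steps no change at the digits printed from compound 1 to compound 3 (within the scatter) and a number 10 percentage points higher from compound 2 to compound 3 (within the scatter), in which propyl, methoxy and propoxy all gave read-outs within the scatter of one another. On that basis compound 4 is expected to sit at the same high level, with the step of a number 5 percentage points lower from compound 3 to compound 4 (within the scatter) expected to fall within the scatter. The estimate for compound 4 is 95%, with a range from 80% to 100%.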

Compound 4, a percentage reported as inhibition, in the whole organism at one dose (the size of the read-out at that dose, not a potency): 100%
Compound 4: the middle estimate sits 5 percentage points below what was measured; measured number inside the range.
By their numbers in this assay, from the lowest: compounds 2, 1, 3 and 4 (each within the scatter of the next).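

In this assay, among the compounds shown here, methylsulfanyl on the aromatic carbon between two ring nitrogen atoms brings sulfur to this position for the first time and gives no change at the digits printed from compound 3 to compound 4 (within the scatter), and the comparisons with the other two groups give no change at the digits printed from compound 1 to compound 4 (within the scatter) and a number 10 percentage points higher from compound 2 to compound 4 (within the scatter). Across these four compounds, therefore, propyl, methoxy, propoxy and methylsulfanyl all give read-outs within the scatter of one another, so the atom bound to the ring can be carbon, oxygen or sulfur, and the group can hold 2 or 4 heavy atoms, without a step beyond the scatter at this single dose. No measurement at hand bears on what lies behind this flat result.

From the compounds shown here alone, whether an amine such as dimethylamino, a carboxylic acid or a longer chain such as hexyloxy on this aromatic carbon would stay at the same level remains open. Also open, going by these compounds, is whether these four compounds would separate at a smaller oral dose or at another time point, since a percentage at one dose gives the size of the read-out and not a potency.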